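Pyridin-2-yl replacing 4-fluorophenyl on the aromatic nitrogen

A few compounds are considered here, and "the series" means these few. Any claim that something is new, unique, unknown or untested is made for them only; others in the source may bear on it.

The series is followed in an assay on isolated protein for inhibition of Myeloperoxidase (Homo sapiens), with a stated time of 10 min; on this read-out lower numbers stand for stronger inhibition and higher numbers for weaker inhibition. Within the data shown here, compound 1 `Nc1cc(Cc2ccn(-c3ccc(F)cc3)n2)c2nn[nH]c2n1` gives 53 nM and holds the lowest number of the two measured so far. Compound 2 `Nc1cc(Cc2ccn(Cc3cccc(C4CCNCC4)c3)n2)c2nn[nH]c2n1` gives 100 nM in this assay; the two values lie within the usual scatter of each other, so no order between compound 1 and compound 2 can be read from them. Compound 3 `Nc1cc(Cc2ccn(-c3ccccn3)n2)c2nn[nH]c2n1` is not yet measured. It differs from compound 1 by pyridin-2-yl in place of 4-fluorophenyl on an aromatic nitrogen. Among the measured compounds shown here, no measured pair shows a step of this kind, so the size of such a step is unknown from the data at hand. The expected step from compound 1 to compound 3 is a 1.3-fold higher number from compound 1 to compound 3 (0.12 log units; within the scatter), small and without a clear direction beyond the scatter. Compound 3 is therefore expected to give 70 nM in this assay, with a range from 25 nM to 200 nM.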

Compound 3, half-maximal inhibitory concentration: 54 nM
The estimate for compound 3 lay 1.3-fold (0.11 log units) above the measured number; the measured number falls inside the stated range.
By their numbers in this assay, from the lowest: compounds 1, 3 and 2 (each within the scatter of the next).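

In this assay, among these compounds, pyridin-2-yl in place of 4-fluorophenyl on the aromatic nitrogen gives a 1.0-fold higher number from compound 1 to compound 3 (0.01 log units; within the scatter), the only step read so far at this position, and it lies within the scatter. At this position, the assay therefore does not separate a six-membered aromatic ring of carbon only carrying fluorine from a six-membered aromatic ring with a hetero atom, although only pyridin-2-yl carries a hydrogen-bond acceptor. Nothing measured in the series bears on why these two groups read alike.

The compounds shown leave open whether this tolerance holds for groups of another kind on the same nitrogen, such as a primary amine or a carboxylic acid on the aromatic ring. They also leave open whether a longer chain between that nitrogen and the aromatic ring would give a step beyond the scatter.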